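Swapping a Cyclopropyl for a Methoxyethyl Chain

A few compounds are considered here, and "the series" means these few. Any claim that something is new, unique, unknown or untested is made for them only; others in the source may bear on it.

Three close relatives of one core have been measured in an assay on HEK293 cells for displacement of a labelled ligand from corticotropin-releasing factor receptor 1 (Homo sapiens); a lower number here means a stronger inhibitor, a higher number a weaker inhibitor. Compound 1 `CCN(CC1CC1)c1cc(C)nc2c(-c3ccc(Cl)cc3Cl)nn(C)c12` gives 4.4 nM, the highest of the three numbers. Compound 2 `CCCCCN(CC1CC1)c1cc(C)nc2c(-c3ccc(Cl)cc3Cl)nn(C)c12` gives 1.5 nM, and compound 3 `CCCCN(CCCC)c1cc(C)nc2c(-c3c(C)cc(C)cc3Cl)nn(C)c12` gives 2.1 nM. Within the data shown here, the only single-point step among them, a 2.9-fold lower number from compound 1 to compound 2 (0.47 log units; beyond the scatter), lengthens a chain on the amine nitrogen. Compound 4 `CCN(CCCOC)c1cc(C)nc2c(-c3ccc(Cl)cc3Cl)nn(C)c12` differs from compound 1 by 2-methoxyethyl in place of cyclopropyl on a saturated chain carbon bound to a nitrogen on an aromatic ring. Among the measured compounds shown here, no measured step touches that group; the step from compound 1 to compound 2 shows only that a longer chain on this nitrogen is tolerated. The new group is expected to behave much like the one it replaces, so the estimated step is a 1.4-fold higher number from compound 1 to compound 4 (0.13 log units; within the scatter), within the scatter. Compound 4 is therefore expected to give about 6 nM, with a likely range from 2 nM to 18 nM.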

Compound 4, inhibition constant: 12.5 nM
For compound 4 the middle estimate is 2.1-fold (0.32 log units) below the measured one, within the range that was stated.
By their numbers in this assay, from the lowest: compounds 2 and 3 (each within the scatter of the next); then compound 1; then compound 4.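

In this assay, replacing cyclopropyl with 2-methoxyethyl on this saturated chain carbon gives a 2.8-fold higher number from compound 1 to compound 4 (0.45 log units; beyond the scatter), so the exchange is not neutral here. The group at this place therefore matters to the measured number, and the two groups are not interchangeable. Nothing measured here explains the change.

The step removes a ring and adds an oxygen together, so the compounds shown do not tell which of the two matters. Isobutyl, an open chain of carbon only, would separate these two changes at this place.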